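The source may report more compounds than this note shows. Statements on the series, on what has been measured and on what is new or still open speak of the compounds shown alone.

Compound 1 `COc1ccc(C(c2ccccc2O)c2cccc3ccccc23)c(OC)c1OC` gives 17700 nM in a functional assay on MDA-MB-231 cells (Homo sapiens) for inhibition, read by sulforhodamine B assay, with a stated time of 48 h; on this read-out higher numbers stand for weaker inhibition and lower numbers for stronger inhibition.
Compound 2 `C=CCOC(c1ccc(OC)c(OC)c1OC)c1cccc2ccccc12` reaches only a limit of this assay, > 20000 nM.

Compound 2 thus stands at the limit of > 20000 nM in this assay, at which 1 of the 2 values shown sits, with no number of its own. Going by the values given here, its one measured step, an at least 1.1-fold higher number from compound 1 to compound 2 (0.05 log units; that floor lies within the scatter), lies within the scatter. Compound 3 `COc1ccc(C(c2ccc(OCC(=O)O)cc2)c2cccc3ccccc23)c(OC)c1OC` carries 4-(carboxymethoxy)phenyl in place of allyloxy on a saturated chain carbon bound to two aromatic carbons. Among the compounds with values here, only that step bears on this change, and it was small, so no step beyond the scatter is expected in this assay in either direction. Compound 3 is therefore expected at about 20000 nM, between 7000 nM and 60000 nM, which means an estimated a number no higher from compound 2 to compound 3 (the limit leaves the size open).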

Compound 3, half-maximal inhibitory concentration: > 20000 nM
Compound 3 was reported as a limit (the forecaster's own chance of this, stated with the estimate: 55%); the middle value sits exactly at the limit.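

Compound 3 is also only a limit in this assay, so 4-(carboxymethoxy)phenyl, with its added aromatic ring, brings this position no readable number: the limit of > 20000 nM in this assay, at which 2 of the 3 values shown sit.

Measured against 2-hydroxyphenyl, the change gives an at least 1.1-fold higher number from compound 1 to compound 3 (0.05 log units; that floor lies within the scatter). The step between the two limits cannot be read.

From the compounds shown here alone, whether an amine or a longer chain on the saturated chain carbon bound to two aromatic carbons would give a readable number in this assay remains open. So does how compound 2 and compound 3 truly compare.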